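Methoxy removal on the aryl ring: working notes

The source may report more compounds than this note shows. Statements on the series, on what has been measured and on what is new or still open speak of the compounds shown alone.

Compound 1 `CCC1=C(O)c2c(oc(-c3ccc(OC)c(C)c3C)cc2=O)C(CC)(CC)C1=O` gives 0.28 uM in a functional assay on KBVIN cells (Homo sapiens) for antiproliferative activity, read by sulforhodamine B assay, with a stated time of 3 days; on this read-out lower numbers stand for an effect already at smaller amounts and higher numbers for an effect only at larger amounts of compound. Compound 3 `CCC1=C(O)c2c(oc(-c3cccc(C)c3C)cc2=O)C(CC)(CC)C1=O` gives 0.85 uM in this assay; it differs from compound 1 by hydrogen in place of methoxy on an aromatic carbon, and the step is a 3.0-fold higher number from compound 1 to compound 3 (0.48 log units; beyond the scatter). Compound 2 `CCC1=C(O)c2c(oc(-c3cc(OC)c(OC)c(OC)c3)cc2=O)C(CC)(CC)C1=O` gives 5.6 uM in this assay; the difference between the core of compound 1 and the core of compound 2 is not broken down here. Compound 4 `CCC1=C(O)c2c(oc(-c3cc(OC)cc(OC)c3)cc2=O)C(CC)(CC)C1=O` is not yet measured. It differs from compound 2 by hydrogen in place of methoxy on an aromatic carbon. This is the same kind of change as that from compound 1 to compound 3, but the place is not the same: here the carbon is ortho to two methoxy groups (2 heavy atoms each), there it was ortho to a methyl group and meta to a methyl group; both are para to a large group. For compound 4 a step of a 1.6-fold higher number from compound 2 to compound 4 (0.21 log units; within the scatter) is expected, resting on a 3.0-fold higher number from compound 1 to compound 3 (0.48 log units; beyond the scatter) seen for the same kind of change, with a wider range because the surroundings differ. Compound 4 is estimated at 9 uM, between 3 uM and 30 uM.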

Compound 4, concentration for half-maximal effect: 3.27 uM
Compound 4: middle estimate off by 2.8-fold (0.44 log units), on the high side; the measured number falls inside the stated range.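

In this assay, hydrogen in place of methoxy on an aromatic carbon gives a 1.7-fold lower number from compound 2 to compound 4 (0.23 log units; within the scatter), so on this core the change has no readable effect. The change does not carry over from one core to the other with a constant size: the same change on two cores in this assay, a 3.0-fold higher number (0.48 log units; beyond the scatter) from compound 1 to compound 3 and a 1.7-fold lower number (0.23 log units; within the scatter) from compound 2 to compound 4, 5.2-fold (0.72 log units) apart, beyond the scatter of two such steps. Going by these compounds alone, with only two pairs, and with the methoxy on a carbon ortho to two methoxy groups only in the second pair, this does not show whether the core or the surroundings of the changed carbon set the difference, and it gives no cause.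

Open, as far as these compounds go, is how an amine or a carboxylic acid in place of that methoxy reads on either core. Also open, from the compounds shown here alone, is how the same change reads on a third core.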